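Swapping a hydroxy for a methanesulfonamido on a bridged ring

The source may report more compounds than this note shows. Statements on the series, on what has been measured and on what is new or still open speak of the compounds shown alone.

Compound 1, with structure `CC1(C)[C@@H]2CC[C@@]1(CS(=O)(=O)N1CCN(c3ccc(C(F)(F)F)cn3)CC1)C(O)C2`, carries a hydroxy on a saturated ring carbon of its shared core. In a functional assay on CHO-K1 cells for antagonist activity at C-X-C chemokine receptor type 3 (Homo sapiens), read by FLIPR and calcium flux (a higher number here means a weaker inhibitor, a lower number a stronger inhibitor), compound 1 gives 158 nM, the lowest of the three numbers shown, though its neighbours sit within the usual scatter. Compound 2, with structure `CC1(O)C[C@H]2CC[C@]1(CS(=O)(=O)N1CCN(c3ccc(C(F)(F)F)cn3)CC1)C2(C)C`, gives 200 nM, and compound 3, with structure `CC1(C)[C@@H]2CC[C@@]1(CS(=O)(=O)N1CCN(c3ccc(C(F)(F)F)cn3)CC1)C1(C2)OCCO1`, gives 200 nM. Going by the values given here, the only single-point step among them, a 1.3-fold higher number from compound 1 to compound 2 (0.10 log units; within the scatter), shows that adding a methyl here leaves the inhibition essentially unchanged.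

Compound 4, with structure `CC1(C)[C@@H]2CC[C@@]1(CS(=O)(=O)N1CCN(c3ccc(C(F)(F)F)cn3)CC1)C(NS(C)(=O)=O)C2`, differs from compound 1 by methanesulfonamido in place of hydroxy on a saturated ring carbon. Among the compounds with values here, no measured step replaces the hydroxy itself, and the methanesulfonamido is a larger group than either the methyl of compound 2 or the ring of compound 3. Since the steps to compound 2 and compound 3 stay within the scatter, the expectation for compound 4 in this assay is a small change, if any, leaning toward a slightly higher number: the expected step is a 1.6-fold higher number from compound 1 to compound 4 (0.20 log units; within the scatter). Compound 4 is thus estimated at 250 nM, with a range from 100 nM to 700 nM.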

Compound 4, half-maximal inhibitory concentration: 631 nM
Compound 4: the middle estimate sits 2.5-fold (0.40 log units) below what was measured, within the range that was stated.
By their numbers in this assay, from the lowest: compounds 1, 2 and 3 (each within the scatter of the next); then compound 4.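

Putting methanesulfonamido in place of hydroxy on this saturated ring carbon gives a 4.0-fold higher number from compound 1 to compound 4 (0.60 log units; beyond the scatter) in this assay and is the only step shown that lies beyond the scatter. The shared core therefore does not accept every change here without a measurable cost, even though adding a methyl in the step from compound 1 to compound 2 left the number within the scatter. No measurement shown explains why the methanesulfonamido raises the number.

The compounds shown leave open whether a plain amine or an acetamido group on the same carbon would stay close to compound 1 or move as far as compound 4. From the compounds shown here alone, a methoxy group or a carboxylic acid at this carbon also remains untested in this set, so how far the trend extends beyond these two groups is unknown.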